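Three esters and an untested isopropyl partner

A few compounds are considered here, and "the series" means these few. Any claim that something is new, unique, unknown or untested is made for them only; others in the source may bear on it.

Measured in a functional assay on RAW264.7 cells (Mus musculus) for inhibition, read by ELISA, with a stated time of 24 h; on this read-out lower numbers stand for an effect already at smaller amounts and higher numbers for an effect only at larger amounts of compound:
- Compound 1 `CC/C=C\C[C@H]1C(=O)C=C[C@H]1CC(=O)Oc1ccccc1`: 33000 nM
- Compound 2 `CC/C=C\C[C@H]1C(=O)C=C[C@H]1CC(=O)Oc1ccc(O)cc1`: 23000 nM
- Compound 3 `CC/C=C\C[C@H]1C(=O)C=C[C@H]1CC(=O)OCCOCCO`: 36000 nM

In this assay, compound 3 stands at 36000 nM, within the scatter of both other compounds, so the three cannot be ranked. The next compound, compound 4 `CC/C=C\C[C@H]1C(=O)C=C[C@H]1CC(=O)OC(C)C`, carries isopropyl in place of 2-(2-hydroxyethoxy)ethyl on an oxygen next to a carbonyl group. For the measured compounds named here, no measured compound yet has isopropyl at this place.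

The closest evidence comes from two other exchanges of the group on that oxygen: a 1.1-fold higher number from compound 1 to compound 3 (0.04 log units; within the scatter) and a 1.6-fold higher number from compound 2 to compound 3 (0.19 log units; within the scatter). The hydroxy exchange on the aromatic carbon gave a 1.4-fold lower number from compound 1 to compound 2 (0.16 log units; within the scatter). All three steps stayed within the scatter, and none of the three compounds goes against this flat picture. No step beyond the scatter is therefore expected. The step expected for compound 4 is a 1.2-fold lower number from compound 3 to compound 4 (0.08 log units; within the scatter). The estimate for compound 4 is 30000 nM, with an expected range from 14000 nM to 60000 nM.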

Compound 4, half-maximal effective concentration: 20000 nM
The estimate for compound 4 lay 1.5-fold (0.18 log units) above the measured number; the range from low to high includes it.
By their numbers in this assay, from the lowest: compounds 4, 2, 1 and 3 (each within the scatter of the next).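

In this assay the group on an oxygen next to a carbonyl group was now exchanged for isopropyl, giving a 1.8-fold lower number from compound 3 to compound 4 (0.26 log units; within the scatter) and a 1.2-fold lower number from compound 2 to compound 4 (0.06 log units; within the scatter) and also a 1.7-fold lower number from compound 1 to compound 4 (0.22 log units; within the scatter) so that no exchange at this place has left the scatter. For the compounds shown here, the flat picture, earlier seen only with phenyl, 4-hydroxyphenyl and 2-(2-hydroxyethoxy)ethyl, thus extends to a group of 3 heavy atoms with no ring and with 0 hydrogen-bond donors and 0 hydrogen-bond acceptors. Nothing available bears on why the numbers stay this close.

Whether any group at this place can move the number beyond the scatter remains open, since an amine, a carboxylic acid and a longer carbon chain are not among the compounds shown. Changes away from this oxygen, on the shared core or its side chain, also remain open.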